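This account rests on a few compounds, and the source may have more. Where it says the series, first, only, none or still open, it means among the compounds named here.

Measured so far in a functional assay on NPC-TW01 cells (Homo sapiens) for inhibition, read by MTT assay, with a stated time of 72 h; on this read-out lower numbers stand for stronger inhibition of growth and higher numbers for weaker inhibition of growth:
Compound 1 (`Nc1cc(-c2ccc(Cl)cc2)nn1-c1ccc(Br)cc1`) at 64400 nM as a number
Compound 2 (`CN(C)/C=N/c1c(C=O)c(-c2ccc(Cl)cc2)nn1-c1ccc(Br)cc1`) at > 100000 nM as a limit
Compound 3 (`Nc1c(C=O)c(-c2ccc(Cl)cc2)nn1-c1cccc(Cl)c1`) at > 100000 nM as a limit

Compound 3 has no number, only a limit (the limit of > 100000 nM in this assay, at which 2 of the 3 values shown sit). Compound 4 (`Nc1c(C=O)c(-c2ccc(Cl)cc2)nn1-c1ccc(Br)cc1`) differs from compound 3 by one change (4-bromophenyl in place of 3-chlorophenyl on an aromatic nitrogen), with 4-bromophenyl in place of 3-chlorophenyl on an aromatic nitrogen. Within the data shown here, no measured step shows the size of this change. Compound 1 also carries 4-bromophenyl and gives 64400 nM as a number. Compound 2 carries it too, and its > 100000 nM is a limit. The expected step (a number no higher from compound 3 to compound 4 (the limit leaves the size open)) stays within the scatter, with no clear direction, and a further limit is likely. For compound 4 the estimated value is 100000 nM with an expected range of 45000 nM to 200000 nM in this read-out.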

Compound 4, concentration for 50% growth inhibition: 59700 nM
Beside the measured number, compound 4's estimate is 1.7-fold (0.22 log units) above it; the range from low to high includes it.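

4-bromophenyl in place of 3-chlorophenyl on the aromatic nitrogen gives an at least 1.6-fold lower number from compound 3 to compound 4 (0.22 log units; that floor lies within the scatter) in this assay, the first reading of this change at this position. Freeing the amino group gives an at least 1.6-fold lower number from compound 2 to compound 4 (0.22 log units; that floor lies within the scatter), while formyl in place of hydrogen on an aromatic carbon gives a 1.1-fold lower number from compound 1 to compound 4 (0.03 log units; within the scatter). The first two steps are floors set by limits, not measured sizes: the limit of > 100000 nM in this assay, at which 2 of the 4 values shown sit.

On these data alone, the true size of the change on the aromatic nitrogen remains open. Also open, as far as these compounds go, is how a 4-methoxyphenyl group on that nitrogen, or a carboxylic acid in place of formyl, would read.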